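A few compounds are considered here, and "the series" means these few. Any claim that something is new, unique, unknown or untested is made for them only; others in the source may bear on it.

Compound 1 `Cn1c(-c2ccc(F)cc2)nc2c(NC3CCCC3)ncnc21` and compound 2 `Cn1c(-c2ccccc2)nc2c(NC3CCCCC3)ncnc21` share the same core and were both tested in a functional assay on CHO cells for antagonist activity at adenosine receptor A2b (Homo sapiens), read by 33P incorporation, with a stated time of 20 min; a lower number here means a stronger inhibitor, a higher number a weaker inhibitor. In this assay compound 1 gives only a limit, > 30000 nM. Compound 2 likewise gives only a limit, > 30000 nM. Where compound 1 stands is therefore set by the limit of > 30000 nM in this assay, at which 2 of the 2 values shown sit, and no measured step between two real numbers is available from these two compounds. Compound 3 `Cn1c(-c2ccccc2Cl)nc2c(NC3CCCC3)ncnc21` has not yet been measured in this assay; it differs from compound 1 by 2-chlorophenyl in place of 4-fluorophenyl on an aromatic carbon. On these data alone, with only limits on record, no step size can be drawn from the measured pair, and the direction of the change remains open. Compound 3 is expected to remain near the limit of this assay, with a wide range around that expectation. The estimate for compound 3 in this assay is 30000 nM, between 10000 nM and 100000 nM. For compound 3 the expected step is a number no higher from compound 1 to compound 3 (the limit leaves the size open), not beyond the scatter.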

Compound 3, inhibition constant: > 30000 nM
Compound 3 was reported as a limit (the forecaster's own chance of this, stated with the estimate: 70%); the middle value sits exactly at the limit.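

In this assay, for the compounds shown here, compound 1 and compound 3 are both reported only as limits, so no step between them can be read: the limit of > 30000 nM in this assay, at which 3 of the 3 values shown sit. The compounds shown leave open how strongly, if at all, each acts at this receptor, and whether 2-chlorophenyl in place of 4-fluorophenyl changes that.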